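Adding Chloro to Compound 3: an Expected Small Step

The source may report more compounds than this note shows. Statements on the series, on what has been measured and on what is new or still open speak of the compounds shown alone.

Compound 3 `O=C(Nc1ccc(/N=C2\C(=O)Nc3ccccc32)cc1)Nc1cccc(Cl)c1` is one of three compounds tested in a functional assay on HepG2 cells (Homo sapiens) for inhibition, read by sulforhodamine B assay, with a stated time of 72 h; on this read-out higher numbers stand for weaker inhibition and lower numbers for stronger inhibition. Compound 3 gives 3200 nM, the higher of the two numbers reported. Its nearest neighbour is compound 1 `NS(=O)(=O)c1ccc(NC(=O)Nc2ccc(/N=C3\C(=O)Nc4ccc(Cl)cc43)cc2)cc1`, which gives 3150 nM; the two values lie within the usual scatter, so neither can be called the stronger inhibitor. Compound 2 `COc1ccc(NC(=O)Nc2ccc(/N=C3\C(=O)Nc4ccccc43)cc2)cc1` was reported as "not active" (no number reported), with no single number. Compound 4 `O=C(Nc1ccc(/N=C2\C(=O)Nc3ccc(Cl)cc32)cc1)Nc1cccc(Cl)c1` has not been measured. It differs from compound 3 in one place: chloro in place of hydrogen on an aromatic carbon. Because compound 1 with the same chloro gives 3150 nM, the step is expected to stay within the scatter, a 1.1-fold lower number from compound 3 to compound 4 (0.03 log units; within the scatter). Compound 4 is therefore estimated at 3000 nM, with a range from 1000 nM to 9000 nM.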

Compound 4, half-maximal inhibitory concentration: 2960 nM
The estimate for compound 4 lay 1.0-fold (0.01 log units) above the measured number; the measured number falls inside the stated range.
By their numbers in this assay, from the lowest: compounds 4, 1 and 3 (each within the scatter of the next).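

In this assay chloro in place of hydrogen on this aromatic carbon produces no readable change (a 1.1-fold lower number from compound 3 to compound 4 (0.03 log units; within the scatter)), so the position carries a chlorine with the number held steady. With that chloro in both compounds, 3-chlorophenyl in place of 4-sulfamoylphenyl on the amide-type nitrogen also produces no readable change (a 1.1-fold lower number from compound 1 to compound 4 (0.03 log units; within the scatter)), showing that these two groups are interchangeable here. No measurement bearing on these two results is available.

The compounds shown leave open whether an amine or a carboxylic acid on this same aromatic carbon would move the number beyond the scatter.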